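The source may hold more compounds than are shown below. What is called first, only, known or untested is meant among the compounds shown, and "the series" means these compounds.

Compounds measured so far:
compound 1 `COc1ccc(CNc2nc3cc(N)cc(N)c3nc2-c2ccccc2)cc1OC`: 45700 nM
compound 2 `COc1cc(CNc2nc3cc(N)cc(N)c3nc2-c2ccccc2)cc(OC)c1OC`: < 50200 nM

Among the compounds with values here, compound 1 is the only compound of this set with a numerical value in a functional assay on UO-31 cells (Homo sapiens) for inhibition, read by sulforhodamine B assay, with a stated time of 48 h (a higher number here means a weaker inhibitor of growth, a lower number a stronger inhibitor of growth), where compound 1 gives 45700 nM. For compound 2, this assay reports only a limit, < 50200 nM, and not a number. Within the data shown here, the one step between measured compounds, methoxy in place of hydrogen on an aromatic carbon, is therefore a step that the limit leaves unreadable from compound 1 to compound 2; the reason is the limit of < 50200 nM in this assay, at which 1 of the 2 values shown sits, which leaves the size of that step unreadable.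

Compound 3 `COc1ccc(CNc2nc3cc(N)cc(N)c3nc2-c2ccccc2)cc1` differs from compound 1 by hydrogen in place of methoxy on an aromatic carbon. Among the measured compounds shown here, only the step from compound 1 to compound 2 bears on this change, and its size cannot be read, so there is no measured ground for expecting a step in either direction beyond the usual scatter. The account therefore expects compound 3 to sit close to compound 1, which gives 45700 nM in this assay. The step from compound 1 to compound 3 is estimated as a 1.0-fold lower number from compound 1 to compound 3 (0.01 log units; within the scatter). Compound 3 is expected to give about 45000 nM in this assay, in the range from 18000 nM to 110000 nM.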

Compound 3, concentration for total growth inhibition: 28800 nM
Estimate against measurement, compound 3: 1.6-fold (0.19 log units) above, and the stated range covers the measured number.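

Within the data shown here, the change from 3,4-dimethoxyphenyl to 4-methoxyphenyl gives the first readable step at this position in this assay, a 1.6-fold lower number from compound 1 to compound 3 (0.20 log units; within the scatter), and this is a step that stays within the scatter. Among these compounds, for this one pair, then, the methoxy group that sits ortho to a methoxy group and meta to a large group gives way to hydrogen with no shift that can be told from repeat measurement, which the earlier compounds could not show. Compound 2 still carries only a limit and not a number, < 50200 nM, so the step that adds a methoxy group to compound 1 remains unreadable: the limit of < 50200 nM in this assay, at which 1 of the 3 values shown sits.

The compounds shown leave open whether the methoxy group that remains in compound 3 has any bearing on the number in this assay, since no compound without it stands here. They also leave open whether a group other than hydrogen or methoxy at this place, such as a hydroxyl, a fluorine, an amine or a longer alkoxy chain, would move the number beyond the scatter.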